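This account rests on a few compounds, and the source may have more. Where it says the series, first, only, none or still open, it means among the compounds named here.

Measured so far:
compound 1 `CC(C)c1ccc(Nc2ccc3c(OCCCN4CCN(C)CC4)cccc3n2)cc1` — 2110 nM
compound 2 `CN1CCN(CCCOc2cccc3nc(Nc4cccc(Cl)c4)ccc23)CC1` — "not determined" (no result reported)

Compound 1 carries an isopropyl on the aniline ring and in a functional assay on MDA-MB-231 cells (Homo sapiens) for inhibition, read by sulforhodamine B assay, with a stated time of 48 h (a higher number here means a weaker inhibitor of growth, a lower number a stronger inhibitor of growth), gives 2110 nM. Compound 2 stands nowhere on the numbers: in this assay its entry reads "not determined" (no result reported), so no value anchors it. Compound 3 `CN1CCN(CCCOc2cccc3nc(Nc4cc(Cl)cc(Cl)c4)ccc23)CC1` differs from compound 2 by chloro in place of hydrogen on an aromatic carbon. Among the measured compounds shown here, with no measured step to lean on, the expected change in this assay is small, in no set direction, and likely within the scatter. Compound 3 is estimated at 1800 nM, with a range of 450 nM to 7000 nM.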

Compound 3, concentration for 50% growth inhibition: 1570 nM
Beside the measured number, compound 3's estimate is 1.1-fold (0.06 log units) above it; the measured number falls inside the stated range.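

Compound 2 has no value in this assay, so the added chloro cannot be read on its own. Among the compounds shown here, the one readable comparison is 3,5-dichlorophenyl in place of 4-isopropylphenyl on the nitrogen, which gives a 1.3-fold lower number from compound 1 to compound 3 (0.13 log units; within the scatter), so these two aryl groups are not told apart at this position. No outside data bear on this result.

Still open, as far as these compounds go, is how an amine or a carboxylic acid in place of the chloro groups would read in this assay. From the compounds shown here alone, with only these two values, the range of this position remains unknown.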